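This account rests on a few compounds, and the source may have more. Where it says the series, first, only, none or still open, it means among the compounds named here.

Compound 1 `Cc1ccc(S(=O)(=O)Oc2ccccc2/C=C(\C#N)C(=O)Nc2nnc(Cc3cccc4ccccc34)s2)cc1`: 19%
Compound 2 `Cc1ccc(S(=O)(=O)Oc2ccccc2/C=C(\C#N)C(=O)Nc2nnc(Cc3ccccc3)s2)cc1`: 16%

In a functional assay on HL-60 cells (Homo sapiens) for inhibition, read by CCK-8 assay, with a stated time of 48 h, tested at 20 uM (a higher number here means more inhibition of growth at the concentration tested, a lower number less inhibition of growth), compound 2 gives 16% and stands level with compound 1 within the scatter, as a number 3 percentage points lower from compound 1 to compound 2 (within the scatter) shows. Compound 3 `N#C/C(=C\c1ccccc1OS(=O)(=O)c1ccc(Cl)cc1)C(=O)Nc1nnc(Cc2ccccc2)s1` has chloro in place of methyl on an aromatic carbon, para to a large group: chloro in place of methyl on an aromatic carbon. Going by the values given here, the only measured step, a number 3 percentage points lower from compound 1 to compound 2 (within the scatter), lies elsewhere in the structure, with phenyl in place of naphthalen-1-yl, so it bears on this change only indirectly. No shift beyond the scatter is therefore expected, and the expected change is a number 2 percentage points higher from compound 2 to compound 3 (within the scatter). For compound 3 the estimated value is 18%, with an expected range from 8% to 33%.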

Compound 3, percent growth inhibition at one concentration: 26%
Beside the measured number, compound 3's estimate is 8 percentage points below it; the measured number falls inside the stated range.
By their numbers in this assay, from the lowest: compounds 2, 1 and 3 (each within the scatter of the next).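

In this assay, exchanging 4-methylphenyl for 4-chlorophenyl on the sulfonyl group gives a number 10 percentage points higher from compound 2 to compound 3 (within the scatter). Going by these compounds alone, this is the first reading at this position, which the earlier pair, differing only at the other end of the molecule, could not give, and it shows that chloro can replace methyl here with compound 3 staying level with compound 2. Nothing available explains this result. As far as these compounds go, whether an amine, a methoxy group or a carboxylic acid at this position would move the number beyond the scatter remains open. So does whether chloro would read the same alongside naphthalen-1-yl.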